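Trifluoromethoxy in place of methoxy on the anilino aryl

The source may report more compounds than this note shows. Statements on the series, on what has been measured and on what is new or still open speak of the compounds shown alone.

Among the compounds with values here, compound 2, `COc1ccc(Nc2ncnc3cc(OC)c(OCCCCC(=O)Nc4ccc(S(N)(=O)=O)cc4)cc23)cc1`, gives 14700 nM in a functional assay on A-431 cells (Homo sapiens) for antiproliferative activity, read by MTT assay, with a stated time of 72 h (on this read-out lower numbers stand for stronger inhibition and higher numbers for weaker inhibition), the highest of the two numbers so far. Its nearest neighbour is compound 1, `COc1cc2ncnc(Nc3ccc(Cl)c(C(F)(F)F)c3)c2cc1OCCCCC(=O)Nc1ccc(S(N)(=O)=O)cc1`, which in this assay gives 3910 nM; the change from 4-chloro-3-(trifluoromethyl)phenyl to 4-methoxyphenyl on the ring nitrogen reads a 3.8-fold higher number from compound 1 to compound 2 (0.58 log units; beyond the scatter).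

Compound 3, `COc1cc2ncnc(Nc3ccc(OC(F)(F)F)cc3)c2cc1OCCCCC(=O)Nc1ccc(S(N)(=O)=O)cc1`, differs from compound 2 by trifluoromethyl in place of methyl on an oxygen on an aromatic ring. Within the data shown here, no measured step changes exactly this position; the only step that bears on it is the one from compound 1 to compound 2, where replacing the 4-methoxyphenyl by an aryl carrying chlorine and trifluoromethyl went with a lower number. Compound 3 keeps the oxygen of compound 2 but brings in a trifluoromethyl, so the change is expected to move partway back toward compound 1, though the two cases are not the same.

Compound 3 is therefore expected to give a lower number than compound 2 in this assay, as an estimated 2.1-fold lower number from compound 2 to compound 3 (0.32 log units; beyond the scatter), of modest size. The estimate for compound 3 is 7000 nM, within 2500 nM to 20000 nM.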

Compound 3, half-maximal inhibitory concentration: 22500 nM
For compound 3 the middle estimate is 3.2-fold (0.51 log units) below the measured one, and the stated range ends below it.
By their numbers in this assay, from the lowest: compound 1; then compounds 2 and 3 (each within the scatter of the next).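

In this assay, trifluoromethyl in place of methyl on an oxygen on an aromatic ring reads a 1.5-fold higher number from compound 2 to compound 3 (0.18 log units; within the scatter), so this exchange does not separate the two compounds at this place. The change from 4-chloro-3-(trifluoromethyl)phenyl to 4-(trifluoromethoxy)phenyl reads a 5.8-fold higher number from compound 1 to compound 3 (0.76 log units; beyond the scatter), in the same direction as a 3.8-fold higher number from compound 1 to compound 2 (0.58 log units; beyond the scatter), so among these three compounds the presence of a trifluoromethyl does not by itself go with the lower number of compound 1, whose trifluoromethyl sits directly on the aryl ring rather than on an oxygen. Nothing available on these compounds offers an explanation for this result.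

The compounds shown do not separate the chlorine of compound 1 from its trifluoromethyl, so which of the two goes with its lower number remains open. Also open is how an aryl carrying an amine or a carboxylic acid in place of methoxy would read, and whether a shorter or longer chain in place of the present one would keep the differences seen among these aryl groups.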